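The compounds below may be only part of what the source reports. "The series", "measured", "known", "first", "only" and "open" are said of these compounds alone.

Compound 1 `CC1=C(C(=O)SC(C)C)C(c2ccco2)NC(=O)N1` gives 1% in an assay on membranes from HeLa cells for displacement of a labelled ligand from adenosine receptor A3 (Homo sapiens), read by scintillation counting, with a stated time of 180 min, tested at 1 uM; on this read-out higher numbers stand for more inhibition at the one concentration tested (going by the name of the read-out) and lower numbers for less inhibition.
Compound 2 `CCC(C)OC(=O)C1=C(C)NC(=O)NC1c1ccco1` gives 3% in this assay.

Both measured compounds share one core and show little displacement of the labelled ligand in this assay. Among the compounds with values here, compound 2 holds the higher of the two numbers, but the only step recorded, a number 2 percentage points higher from compound 1 to compound 2 (within the scatter), lies within the scatter, so the two compounds read as alike rather than ordered.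

Compound 3 `CC1=C(C(=O)OC2CCC2)C(c2ccco2)NC(=O)N1` is the compound not yet measured. It differs from compound 2 in one place: cyclobutyl in place of sec-butyl on an oxygen next to a carbonyl group. Within the data shown here, no measured step exchanges one alkyl group for another on this oxygen; the single step that exists, a number 2 percentage points higher from compound 1 to compound 2 (within the scatter), replaced the whole isopropylsulfanyl group by sec-butoxy and still moved nothing beyond the scatter. With both measured compounds sitting near the bottom of the read-out, the expectation for compound 3 is that the change from sec-butyl to cyclobutyl brings no step beyond the scatter, so the step from compound 2 to compound 3 is estimated as no change at the digits printed from compound 2 to compound 3 (within the scatter). Compound 3 is therefore expected to give about 3% in this assay, with a range from -6% to 12%.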

Compound 3, a percentage reported as inhibition, at one concentration (the size of the read-out at that concentration, not a potency): 1%
Compound 3: middle estimate off by 2 percentage points, on the high side, and the stated range covers the measured number.
By their numbers in this assay, from the lowest: compounds 1, 3 and 2 (each within the scatter of the next).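

At this oxygen next to a carbonyl group, one alkyl group now stands in for another, and cyclobutyl in place of sec-butyl gives a number 2 percentage points lower from compound 2 to compound 3 (within the scatter) in this assay, so the four-membered ring does not set these two compounds apart. Within the data shown here, the comparison at the carbonyl carbon gives no change at the digits printed from compound 1 to compound 3 (within the scatter) for cyclobutyloxy in place of isopropylsulfanyl, which adds a second exchange of this whole group that separates no compounds, and all three compounds read as alike near the bottom of the read-out. Nothing measured here bears on why these exchanges leave the compounds indistinguishable.

From the compounds shown here alone, it remains open whether any group at this place could lift the number beyond the scatter, such as a longer chain like octyl, a benzyl group, or an alkyl chain ending in an amine or a carboxylic acid in place of cyclobutyl. With all three numbers so close to the bottom of the read-out, the compounds shown also cannot tell whether the choice among sec-butyl, cyclobutyl and the isopropylsulfanyl exchange would matter on a compound that displaces more of the labelled ligand.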